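The source may hold more compounds than are shown below. What is called first, only, known or untested is meant among the compounds shown, and "the series" means these compounds.

Series notes: two aryl ureas measured, one pair awaiting a number.

Compound 1 `C[C@H](NC(=O)Nc1cccc(F)c1)c1ccccc1` and compound 2 `C[C@@H](NC(=O)Nc1cccc(Cl)c1)c1ccccc1` have each been run in an ADME assay on the whole organism with Oryza sativa as the target, tested at 10 uM; a lower number here means a stronger effect, a higher number a weaker effect of the compound at the concentration tested. In this assay compound 1 gives 88%. In this assay compound 2 gives 83%. Among the measured compounds shown here, these are the only two numbers in hand, and the gap between compound 2 and compound 1 is within the scatter of repeated measurements, so the two cannot be told apart on this basis. For the measured compounds named here, no step between two measured compounds that differ in one place is available, so nothing is known yet about how a single change moves the read-out.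

The next compound, compound 3 `C[C@H](NC(=O)Nc1cccc(Cl)c1)c1ccccc1`, is still to be measured in this assay. It relates to compound 2 as follows: the two compounds have the same atoms and bonds and differ only in configuration as drawn: 1 of 1 stereo elements differ; a stereocentre at a saturated chain carbon is drawn R in compound 2 and S in compound 3. Nothing leaves and nothing enters; the one stereocentre at the saturated chain carbon is drawn R in compound 2 and S in compound 3.

Going by the values given here, with no measured step of this kind, the expected step from the first to the second, a number 2 percentage points higher from compound 2 to compound 3 (within the scatter), is none beyond the scatter, in either direction. For compound 3 the estimate in this assay is 85%, with a range from 72% to 95%.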

Compound 3, a percentage reported as activity, at one concentration (the size of the read-out at that concentration, not a potency): 103%
Compound 3: middle estimate off by 18 percentage points, on the low side, outside the stated range (above it).
By their numbers in this assay, from the lowest: compounds 2 and 1 (each within the scatter of the next); then compound 3.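

The saturated chain carbon is now shown to matter in this assay: turning its one stereocentre from R to S gives a number 20 percentage points higher from compound 2 to compound 3 (beyond the scatter), and since a higher number means a weaker effect, the S form with chloro is the weaker of that pair. This step can be assigned to the stereocentre alone because the pair offers no other difference, as one fact establishes: the fact that compounds 2 and 3 differ only in the configuration as drawn. The aromatic carbon also responds, with the configuration as drawn held the same: chloro in place of fluoro gives a number 15 percentage points higher from compound 1 to compound 3 (beyond the scatter), so a single change at either place moves the read-out beyond the scatter, which the first two numbers alone could not show.

Still open, from the compounds shown here alone, is whether the step between the two configurations keeps its direction and size with fluoro in place of chloro, since only the chloro pair shows it. Also open, going by these compounds, is how a bromo or a methoxy group on the same aromatic carbon would compare with chloro and fluoro, and whether the read-out of either configuration would follow the same order with such a group.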